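The source may report more compounds than this note shows. Statements on the series, on what has been measured and on what is new or still open speak of the compounds shown alone.

Measured compounds:
compound 1 `CCN1C(=O)S/C(=C\c2ccc(N)cc2)C1=O` — 76000 nM
compound 2 `Nc1ccc(/C=C2\SC(=O)N(Cc3ccc(C(F)(F)F)cc3)C2=O)cc1` — 134000 nM
compound 3 `Nc1ccc(/C=C2\SC(=O)N(Cc3cccc(Cl)c3)C2=O)cc1` — 10000 nM

In a functional assay on FM3A cells (Mus musculus) for cytotoxicity, read by cell counting, with a stated time of 2 days (on this read-out lower numbers stand for stronger inhibition and higher numbers for weaker inhibition), compound 3 gives the lowest number of the three, with compound 1 a 7.6-fold lower number from compound 1 to compound 3 (0.88 log units; beyond the scatter) away and compound 2 further still. Compound 4 `Nc1ccc(/C=C2\SC(=O)N(Cc3ccc(Cl)cc3)C2=O)cc1` differs from compound 3 only in the arrangement of the same atoms: 4-chlorophenyl in place of 3-chlorophenyl on a saturated chain carbon bound to an amide-type nitrogen in a ring. For the measured compounds named here, no measured step covers a change of this kind; the one measured step, a 7.6-fold lower number from compound 1 to compound 3 (0.88 log units; beyond the scatter), concerns a different replacement, and the values of compound 2 and compound 3 show only that the two aryl groups tried here differ widely. A moderate rise in the number is therefore expected for compound 4, a 3.0-fold higher number from compound 3 to compound 4 (0.48 log units; beyond the scatter), giving an estimated 30000 nM with a range of 8000 nM to 120000 nM.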

Compound 4, half-maximal inhibitory concentration: 60000 nM
Compound 4: the middle estimate sits 2.0-fold (0.30 log units) below what was measured; measured number inside the range.
By their numbers in this assay, from the lowest: compound 3; then compounds 4, 1 and 2 (each within the scatter of the next, the first and the last beyond it).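

In this assay, 4-chlorophenyl in place of 3-chlorophenyl gives a 6.0-fold higher number from compound 3 to compound 4 (0.78 log units; beyond the scatter) and so shows that the arrangement of the same atoms on this aryl group matters at this place. With the aryl group kept, chloro in place of trifluoromethyl gives a 2.2-fold lower number from compound 2 to compound 4 (0.35 log units; beyond the scatter) as a further modest step. Against methyl on the same chain carbon, 4-chlorophenyl gives a 1.3-fold lower number from compound 1 to compound 4 (0.10 log units; within the scatter) and so, unlike 3-chlorophenyl, stands no clearer of methyl than the scatter allows.

On these data alone, whether a methoxy group or a nitrile on this aryl ring, or a longer chain in place of it, would change the number remains open. Nothing given here accounts for these differences.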